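A few compounds are considered here, and "the series" means these few. Any claim that something is new, unique, unknown or untested is made for them only; others in the source may bear on it.

Compounds measured so far: compound 1 `CC(C)(C)c1ccc(Cn2cc(-c3cn([C@H]4C[C@H](O)[C@@H](CO)O4)c(=O)[nH]c3=O)nn2)cc1` gives 102% in a functional assay on ACHN cells (Homo sapiens) for cytotoxicity, read by sulforhodamine B assay, tested at 10 uM; a higher number here means more inhibition at the concentration tested (going by the name of the read-out), a lower number less inhibition; compound 2 `CC(=O)OC[C@H]1O[C@@H](n2cc(-c3cc(C)no3)c(=O)[nH]c2=O)C[C@@H]1OC(C)=O` gives 96.4%; compound 3 `CCCCCc1cc(-c2cn([C@H]3C[C@H](OC(C)=O)[C@@H](COC(C)=O)O3)c(=O)[nH]c2=O)on1` gives 99.8%.

Compound 3 sits among these three numbers with both its neighbours within the usual scatter: its gap to compound 1 and its gap to compound 2 are each too small to rank. For the measured compounds named here, the one step already measured on the shared core, a number 3.4 percentage points higher from compound 2 to compound 3 (within the scatter), changed a chain on a saturated carbon and moved the read-out by an amount within the scatter, so the number in this assay stays level across that substituent.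

Compound 4 `CC(=O)OC[C@H]1O[C@@H](n2cc(-c3cc(-c4ccc(C(C)C)cc4)no3)c(=O)[nH]c2=O)C[C@@H]1OC(C)=O` differs from compound 3 by 4-isopropylphenyl in place of pentyl on an aromatic carbon. Going by the values given here, no measured step swaps a chain for an aromatic group at this position, so the only guide is the flatness seen across compounds 1, 2 and 3. He therefore expects for compound 4 in this assay a step of a number 2.8 percentage points lower from compound 3 to compound 4 (within the scatter), none beyond the scatter. His estimate for compound 4 is 97%, with a range from 85% to 103%.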

Compound 4, a percentage reported as inhibition, at one concentration (the size of the read-out at that concentration, not a potency): 90.1%
Compound 4: the middle estimate sits 6.9 percentage points above what was measured, within the range that was stated.
By their numbers in this assay, from the lowest: compounds 4, 2, 3 and 1 (each within the scatter of the next, the first and the last beyond it).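

In this assay, the carbon next to the ring nitrogen of the five-membered aromatic ring now carries an aromatic group rather than a chain: 4-isopropylphenyl in place of pentyl gives a number 9.7 percentage points lower from compound 3 to compound 4 (within the scatter), and 4-isopropylphenyl in place of methyl gives a number 6.3 percentage points lower from compound 2 to compound 4 (within the scatter). Both steps lie within the scatter, so this read-out does not separate methyl, pentyl and 4-isopropylphenyl at this place, although the entering group adds a six-membered aromatic ring. No measurement on these compounds accounts for this result.

From the compounds shown here alone, whether an amine or a carboxylic acid at this place would leave the number level remains open. Because each value is the size of the read-out at a single concentration, these compounds also leave open how their potencies compare.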